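Compound 3 and a step at the assay limit

The source may report more compounds than this note shows. Statements on the series, on what has been measured and on what is new or still open speak of the compounds shown alone.

Going by the values given here, in an ADME assay on Huh-7 cells (Homo sapiens) for cytotoxicity, with a stated time of 72 h (on this read-out higher numbers stand for lower toxicity in this test and lower numbers for higher toxicity in this test), no tested compound has yet given a number. Compound 1 `CC(C)CCn1nc(-c2cccs2)c(O)c(C2=NS(=O)(=O)c3cc(CS(C)(=O)=O)ccc3N2)c1=O` reads > 33000 nM as a limit of the assay. Compound 2 `CS(=O)(=O)Nc1ccc2c(c1)S(=O)(=O)N=C(c1c(O)c(-c3ccsc3)nn(CCC3CC3)c1=O)N2` reads > 1000 nM as a limit too. Compound 3 `CC(C)CCn1nc(CC2=CCCC2)c(O)c(C2=NS(=O)(=O)c3cc(NS(C)(=O)=O)ccc3N2)c1=O` reads > 33000 nM and so stands only at a limit, namely the limit of > 33000 nM in this assay, at which 2 of the 3 values shown sit, and no exact value. The change 2,2,2-trifluoroethyl in place of cyclopent-1-en-1-yl on a saturated chain carbon bound to an aromatic carbon puts 2,2,2-trifluoroethyl in place of cyclopent-1-en-1-yl on a saturated chain carbon bound to an aromatic carbon and gives compound 4 `CC(C)CCn1nc(CCC(F)(F)F)c(O)c(C2=NS(=O)(=O)c3cc(NS(C)(=O)=O)ccc3N2)c1=O` as the result. In this assay the expected step of a number no higher from compound 3 to compound 4 (the limit leaves the size open) is none beyond the scatter, in neither direction. Compound 4 is estimated near 33000 nM with an expected range from 12000 nM to 50000 nM and probably only a limit reported.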

Compound 4, half-maximal cytotoxic concentration: > 33000 nM
Compound 4: only a limit was reported; the forecaster's own chance of this, stated with the estimate: 85%; the middle value lies on the limit itself.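

Going by these compounds alone, compound 3 and compound 4 both give only a limit, and no step between them can be read. The compounds shown leave open where any of them would fall as an exact number in this assay and whether 2,2,2-trifluoroethyl in place of cyclopent-1-en-1-yl shifts that number.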